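This account rests on a few compounds, and the source may have more. Where it says the series, first, only, none or still open, it means among the compounds named here.

In a functional assay on MIA PaCa-2 cells (Homo sapiens) for antiproliferative activity, read by WST assay, with a stated time of 72 h (on this read-out lower numbers stand for stronger inhibition and higher numbers for weaker inhibition), the three measured compounds share one core and differ only in the groups hung on it. Compound 1 `COc1ccc2[nH]c(-c3nc(C)no3)cc2c1` returns only a limit of the assay in this assay, > 50000 nM. Compound 2 `COc1ccc2[nH]c(-c3nc(-c4ccccc4)no3)cc2c1` gives a number in this assay, 32600 nM. Going by the values given here, the single measured step, an at least 1.5-fold lower number from compound 1 to compound 2 (0.18 log units; that floor lies within the scatter), has a floor that lies inside the usual scatter, so it shows no clear change. Compound 3 `COc1ccc(-c2noc(-c3cc4ccccc4[nH]3)n2)cc1` likewise returns only a limit of the assay in this assay, > 50000 nM. The picture is therefore dominated by the limit of > 50000 nM in this assay, at which 2 of the 3 values shown sit, and compound 3 stands at that limit rather than at a number.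

Compound 4 `COc1ccc(-c2noc(-c3cc4cc(OC)ccc4[nH]3)n2)cc1` has not been measured. It differs from compound 3 by methoxy in place of hydrogen on an aromatic carbon. Among the compounds with values here, no measured step involves this change, and the only step that exists concerns a different position and is within the scatter. Compound 4 is thus expected to give 50000 nM in this assay, inside the range 15000 nM to 100000 nM. The expected step of a number no higher from compound 3 to compound 4 (the limit leaves the size open) is small, and a further limit is quite likely.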

Compound 4, half-maximal inhibitory concentration: 5600 nM
Compound 4: middle estimate off by 8.9-fold (0.95 log units), on the high side; the whole stated range lies above it.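

Methoxy on the six-membered ring of the fused two-ring system, in place of hydrogen, gives the first step beyond the scatter in this assay: an at least 8.9-fold lower number from compound 3 to compound 4 (0.95 log units; beyond the scatter). The methoxy on the phenyl ring counts as well, since 4-methoxyphenyl in place of phenyl gives a 5.8-fold lower number from compound 2 to compound 4 (0.77 log units; beyond the scatter), and 4-methoxyphenyl in place of methyl gives an at least 8.9-fold lower number from compound 1 to compound 4 (0.95 log units; beyond the scatter). Only compound 4 carries both methoxy groups, and it alone stands clearly apart from the other compounds, though two of its steps are only floors, as the compounds they start from sit at a limit: the limit of > 50000 nM in this assay, at which 2 of the 4 values shown sit.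

From the compounds shown here alone, whether ethoxy, hydroxyl or an amine at this carbon would keep the gain stays open. The compounds shown also carry methoxy at only one carbon of the fused rings, so other carbons of that ring remain unknown.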